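This account rests on a few compounds, and the source may have more. Where it says the series, first, only, none or still open, it means among the compounds named here.

Measured compounds:
compound 1, `C=CCCn1c(=O)c2[nH]cnc2n(CCC)c1=O`, 200 nM
compound 2, `CCCn1c(=O)n(CCOCC)c(=O)c2[nH]cnc21`, 70 nM
compound 3, `CCCn1c(=O)n(C)c(=O)c2c1ncn2CC(N)=O`, > 100000 nM

All values come from a functional assay (trachea) with Cavia porcellus as the target; a higher number here means that more compound is needed for the effect, a lower number that less compound is needed. Compound 1 and compound 2 give numbers; compound 3 does not. The value of compound 3 is a limit of the assay and not a number, so compound 3 stands at the limit of > 100000 nM in this assay, at which 1 of the 3 values shown sits, the weakest position the numbers shown allow to be stated.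

The step now followed goes from compound 3 to compound 4, `CCCn1c(=O)n(C)c(=O)c2c1ncn2CC(C)=O`, which is still to be measured in this assay. The change is methyl in place of amino on a carbonyl carbon.

Among the measured compounds shown here, the one step measured, a 2.9-fold lower number from compound 1 to compound 2 (0.46 log units; beyond the scatter), concerns a different place: a substituent on a chain carbon two bonds from an aromatic nitrogen, not a carbonyl carbon. For the measured compounds named here, it therefore does not bear directly on the change from compound 3 to compound 4, and no measured step speaks to the exchange of amino for methyl on a carbonyl carbon. The starting point is itself only a limit, so the expectation carries little weight.

With nothing to pull the number down, compound 4 is expected to remain near the limit, estimated at 100000 nM with a range from 20000 nM to 500000 nM. The step this estimate implies is a number no higher from compound 3 to compound 4 (the limit leaves the size open), with a real chance that only a limit is again reported.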

Compound 4, half-maximal effective concentration: 1900 nM
Compound 4: the middle estimate sits 53-fold (1.72 log units) above what was measured; the whole stated range lies above it.
By their numbers in this assay, from the lowest: compound 2; then compound 1; then compound 4. At a limit, above all of these: compound 3.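

In this assay, the exchange of amino for methyl on a carbonyl carbon gives an at least 52-fold lower number from compound 3 to compound 4 (1.72 log units; beyond the scatter), so this place, untouched by the earlier step on the chain, clearly responds to the group it carries. Compound 4, with 2-oxopropyl in place of carbamoylmethyl, gives a real number of 1900 nM, so the hydrogen-bond donor of the amino group is not needed for a measurable effect in this pair. The full size of the step stays open, since compound 3 is given only as a limit and not as a number: the limit of > 100000 nM in this assay, at which 1 of the 4 values shown sits.

This single pair cannot separate the loss of the amino group from the arrival of the methyl, and compound 1 and compound 2 differ from compound 4 in more than one place, so they do not help to settle it. Also open, from the compounds shown here alone, is how a longer chain such as ethyl, or a hydroxyl group giving a carboxylic acid, would fare on the same carbonyl carbon.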